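The source may report more compounds than this note shows. Statements on the series, on what has been measured and on what is new or still open speak of the compounds shown alone.

Within the data shown here, the compounds measured so far are compound 1 `O=S(=O)(/C=C/c1ccc(Br)cc1)Cc1ccc(Nc2ncnc3ccccc23)cc1`, compound 2 `CC(C)(C)c1cc(/C=C/S(=O)(=O)Cc2ccc(Nc3ncnc4ccccc34)cc2)cc(C(C)(C)C)c1O` and compound 3 `O=S(=O)(/C=C/c1ccc(Cl)cc1)Cc1ccc(Nc2ncnc3ccccc23)cc1`. In a functional assay on HT-29 cells (Homo sapiens) (on this read-out lower numbers stand for stronger inhibition of growth and higher numbers for weaker inhibition of growth), compound 1 gives only a limit, > 100000 nM. Compound 2 gives 17000 nM, and compound 3 gives 73000 nM. Compound 1 thus stands at the limit (the limit of > 100000 nM in this assay, at which 1 of the 3 values shown sits), without a number of its own. The unmeasured compound 4 `O=S(=O)(/C=C/c1ccc(O)cc1)Cc1ccc(Nc2ncnc3ccccc23)cc1` differs from compound 1 by a single change: hydroxy in place of bromo on an aromatic carbon. Among the measured compounds shown here, the only measured step here, an at least 1.3-fold lower number from compound 1 to compound 3 (0.13 log units; that floor lies within the scatter), swaps one halogen for another and says little about a hydroxy. Compound 2, which also carries a hydroxy on that ring, does reach a number in this assay. Compound 4 is therefore expected to reach a number as well, with the step of an at least 2.5-fold lower number from compound 1 to compound 4 (0.39 log units; beyond the scatter). The estimated value of compound 4 is 40000 nM, in the range 10000 nM to 150000 nM.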

Compound 4, concentration for 50% growth inhibition: 2000 nM
Compound 4: the middle estimate sits 20-fold (1.30 log units) above what was measured; the whole stated range lies above it.
By their numbers in this assay, from the lowest: compound 4; then compound 2; then compound 3. At a limit, above all of these: compound 1.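

On this aromatic carbon, para to a large group, the exchange of one halogen for the other gave no step beyond the scatter, whereas hydroxy in this assay gives an at least 50-fold lower number from compound 1 to compound 4 (1.69 log units; beyond the scatter) and a 37-fold lower number from compound 3 to compound 4 (1.56 log units; beyond the scatter). The position therefore responds strongly to the group it carries, and the change from halogen to hydroxy is large. The first of these steps is only a floor, since compound 1 has no number of its own: the limit of > 100000 nM in this assay, at which 1 of the 4 values shown sits.

As far as these compounds go, whether an amine, a methoxy or a carboxylic acid on this carbon would match hydroxy stays open.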